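Phenyl in Place of Thiophen-3-yl on a Shared Core

This account rests on a few compounds, and the source may have more. Where it says the series, first, only, none or still open, it means among the compounds named here.

Compound 1 `Nc1nc(N)c2c(-c3ccsc3)cn([C@@H]3O[C@H](CO)[C@@H](O)[C@H]3O)c2n1` gives > 20000 nM.
Compound 2 `Cc1nc(N)c2c(-c3cc4ccccc4o3)cn([C@@H]3O[C@H](CO)[C@@H](O)[C@H]3O)c2n1` gives 15700 nM.
Compound 3 `Cc1nc(N)c2c(-c3ccsc3)cn([C@@H]3O[C@H](CO)[C@@H](O)[C@H]3O)c2n1` gives > 20000 nM.

In a functional assay on K562 cells (Homo sapiens), read by MTT assay, with a stated time of 72 h (on this read-out higher numbers stand for weaker inhibition and lower numbers for stronger inhibition), compound 3 gives only a limit of the assay, > 20000 nM. Compound 1 likewise gives only a limit. Compound 2 gives a number, 15700 nM, and the step of an at least 1.2-fold higher number from compound 2 to compound 3 (0.10 log units; that floor lies within the scatter) stays small. The step that the two limits leave unreadable from compound 1 to compound 3 cannot be read because both ends sit at the limit of > 20000 nM in this assay, at which 2 of the 3 values shown sit. Compound 4 `Cc1nc(N)c2c(-c3ccccc3)cn([C@@H]3O[C@H](CO)[C@@H](O)[C@H]3O)c2n1` differs from compound 3 by phenyl in place of thiophen-3-yl on an aromatic carbon. Among the compounds with values here, no measured step exchanges these two groups; the nearest comparison, one aromatic ring for another in an at least 1.2-fold higher number from compound 2 to compound 3 (0.10 log units; that floor lies within the scatter), changed little. No step beyond the scatter is therefore expected, and compound 4 is estimated at 20000 nM (range 8000 nM to 50000 nM), a step of a number no higher from compound 3 to compound 4 (the limit leaves the size open), with a fair chance that this assay again reports only a limit.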

Compound 4, half-maximal inhibitory concentration: > 20000 nM
Compound 4 was reported as a limit; the forecaster's own chance of this, stated with the estimate: 60%; the middle value sits exactly at the limit.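

Phenyl on this aromatic carbon, like thiophen-3-yl, leaves the value at a limit in this assay, so the step between these two compounds and any other step between two limits cannot be read: the limit of > 20000 nM in this assay, at which 3 of the 4 values shown sit.

Set against the only measured number, the change from 1-benzofuran-2-yl to phenyl gives an at least 1.2-fold higher number from compound 2 to compound 4 (0.10 log units; that floor lies within the scatter). A six-membered aromatic ring of carbon only therefore gives no readable value here either.

Going by these compounds, whether a carboxylic acid or an amine on the phenyl ring would bring a readable number stays open. So does whether a value well clear of the limit can be reached at this position at all.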